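This account rests on a few compounds, and the source may have more. Where it says the series, first, only, none or still open, it means among the compounds named here.

Measured so far in a functional assay on HepG2 cells (Homo sapiens) for inhibition, read by MTT assay, with a stated time of 72 h; a higher number here means a weaker inhibitor, a lower number a stronger inhibitor:
compound 1 `CN(C(=O)NC(=O)c1ccc(F)c(F)c1)c1nc(C(F)(F)F)c(C(=O)N/N=C/c2ccc(C(F)(F)F)cc2)s1`, 6.26 ug/mL
compound 2 `CN(C(=O)NC(=O)c1ccc(Cl)cc1Cl)c1nc(C(F)(F)F)c(C(=O)N/N=C/c2ccc(C(F)(F)F)cc2)s1`, 12.4 ug/mL

For the measured compounds named here, only two compounds have been measured, and they differ in one place: a 2.0-fold higher number from compound 1 to compound 2 (0.30 log units; within the scatter). Compound 2 therefore has no neighbour whose number sits clearly apart from its own; the two values are within the scatter of each other.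

Compound 3 `CN(C(=O)NC(=O)c1cccc(C(F)(F)F)c1)c1nc(C(F)(F)F)c(C(=O)N/N=C/c2ccc(C(F)(F)F)cc2)s1` is the next compound in this series. It differs from compound 2 in one place: 3-(trifluoromethyl)phenyl in place of 2,4-dichlorophenyl on a carbonyl carbon. Going by the values given here, the only step that bears on this change is the exchange of one ring for another at the same carbonyl carbon, from compound 1 to compound 2, and that step stayed within the scatter. No step beyond the scatter is therefore expected for compound 3 in this assay, in either direction. The estimate for compound 3 is 9.5 ug/mL, with a range from 4 ug/mL to 22 ug/mL, which corresponds to the expected step of a 1.3-fold lower number from compound 2 to compound 3 (0.12 log units; within the scatter).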

Compound 3, half-maximal inhibitory concentration: 7.71 ug/mL
Beside the measured number, compound 3's estimate is 1.2-fold (0.09 log units) above it; the range from low to high includes it.
By their numbers in this assay, from the lowest: compounds 1, 3 and 2 (each within the scatter of the next).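

In this assay a third substituted phenyl ring at this carbonyl carbon gives a 1.6-fold lower number from compound 2 to compound 3 (0.21 log units; within the scatter) and also a 1.2-fold higher number from compound 1 to compound 3 (0.09 log units; within the scatter) when set against the other ring. The entering 3-(trifluoromethyl)phenyl has 10 heavy atoms and fluorine, where 2,4-dichlorophenyl has 8 and chlorine, yet the two cannot be told apart in this assay, and neither can 3-(trifluoromethyl)phenyl and 3,4-difluorophenyl. Nothing measured here offers an explanation for these close numbers.

The compounds shown leave open whether any group at this carbonyl carbon would move the number beyond the scatter, since all three are substituted phenyl rings. A plain phenyl ring, a ring carrying an amine or a carboxylic acid, or a simple alkyl chain could each test this.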